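Working notes: from compound 3 to compound 4

The source may hold more compounds than are shown below. What is called first, only, known or untested is meant among the compounds shown, and "the series" means these compounds.

Measured in a functional assay on RKOp27 cells (Homo sapiens) for cytotoxicity, read by MTT assay, with a stated time of 3 days; on this read-out higher numbers stand for weaker inhibition and lower numbers for stronger inhibition:
- compound 1 `N#Cc1c(O)nc(SCc2nc3ccccc3[nH]2)nc1-c1ccccc1`: 6.09 nM
- compound 2 `N#Cc1c(Cl)nc(SCc2nc3ccccc3[nH]2)nc1-c1ccccc1`: 4.38 nM
- compound 3 `N#Cc1c(NN)nc(SCc2nc3ccccc3[nH]2)nc1-c1ccccc1`: 2.55 nM

Compound 3 stands at 2.55 nM in this assay, and its number lies within the scatter of the number for compound 2, as shown by a 1.7-fold lower number from compound 2 to compound 3 (0.23 log units; within the scatter). Its gap to compound 1 is modest but goes beyond the scatter, at a 2.4-fold lower number from compound 1 to compound 3 (0.38 log units; beyond the scatter).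

The next structure is compound 4 `N#Cc1c(Nc2ccccc2)nc(SCc2nc3ccccc3[nH]2)nc1-c1ccccc1`, which carries phenyl in place of amino on a nitrogen on an aromatic ring, that is, phenyl in place of amino on a nitrogen on an aromatic ring. The bearing evidence is the set of exchanges on the same aromatic carbon. Besides the two steps above, these include a 1.4-fold lower number from compound 1 to compound 2 (0.14 log units; within the scatter). Within the data shown here, all three steps are small, but none of them places a ring at this position, so the data offer no direct precedent for the change.

A large step is not expected, because a 2.4-fold lower number from compound 1 to compound 3 (0.38 log units; beyond the scatter) is the biggest seen in the series. The expected move is a 1.4-fold higher number from compound 3 to compound 4 (0.14 log units; within the scatter), a slightly higher number that remains a tentative direction. Compound 4 is estimated at 3.5 nM, with an expected range of 1.2 nM to 9 nM.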

Compound 4, half-maximal inhibitory concentration: 4.9 nM
Compound 4: the middle estimate sits 1.4-fold (0.15 log units) below what was measured; the measured number falls inside the stated range.
By their numbers in this assay, from the lowest: compounds 3, 2, 4 and 1 (each within the scatter of the next, the first and the last beyond it).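

Compound 4 is the only compound shown that carries a ring at this position, and in this assay the exchange of amino for phenyl on a nitrogen on an aromatic ring gives a 1.9-fold higher number from compound 3 to compound 4 (0.28 log units; within the scatter). Compared with the chloro and hydroxy compounds, the anilino group gives a 1.1-fold higher number from compound 2 to compound 4 (0.05 log units; within the scatter) and a 1.2-fold lower number from compound 1 to compound 4 (0.09 log units; within the scatter), so in this assay a phenyl ring is taken up at this position with no step to any of the three earlier compounds beyond the scatter. Nothing at hand bears on why the numbers stay this close.

Still open, from the compounds shown here alone, is whether a phenyl ring carrying a methoxy group or a carboxylic acid, or a morpholine on the same aromatic carbon, would stay within this narrow range of numbers. Also open, going by these compounds, is whether a benzylamino group or a longer alkyl chain on the same nitrogen would produce a step beyond the scatter.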